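The source may report more compounds than this note shows. Statements on the series, on what has been measured and on what is new or still open speak of the compounds shown alone.

Measured compounds:
compound 1 `C=CC(=O)Nc1cccc(NC(=O)CSc2nc(Nc3ccccc3)c3ccccc3n2)c1`: 10200 nM
compound 2 `C=CC(=O)Nc1cccc(NC(=O)CSc2nc(Nc3ccccc3C)c3ccccc3n2)c1`: 20400 nM

In a functional assay on MDA-MB-231 cells (Homo sapiens) for inhibition, read by MTT assay, with a stated time of 72 h (on this read-out lower numbers stand for stronger inhibition and higher numbers for weaker inhibition), compound 2 gives the higher of the two numbers, though only a 2.0-fold higher number from compound 1 to compound 2 (0.30 log units; within the scatter) separates it from compound 1, a difference within the scatter. Compound 3 `C=CC(=O)Nc1cccc(NC(=O)CSc2nc(Nc3cccc(Cl)c3)c3ccccc3n2)c1` differs from compound 2 by 3-chlorophenyl in place of 2-methylphenyl on a nitrogen on an aromatic ring. Among the compounds with values here, no measured step involves a chlorine substitution, and the only step known, the methyl addition from compound 1 to compound 2, stayed within the scatter. Compound 3 is therefore expected to show a 1.4-fold lower number from compound 2 to compound 3 (0.13 log units; within the scatter), no change beyond the scatter. The estimate for compound 3 in this assay is 15000 nM, with a range from 5000 nM to 45000 nM.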

Compound 3, half-maximal inhibitory concentration: 16300 nM
Compound 3: the middle estimate sits 1.1-fold (0.04 log units) below what was measured; low and high end bracket the measured number.
By their numbers in this assay, from the lowest: compounds 1, 3 and 2 (each within the scatter of the next).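

In this assay, 3-chlorophenyl in place of 2-methylphenyl on this nitrogen gives a 1.3-fold lower number from compound 2 to compound 3 (0.10 log units; within the scatter), and chloro in place of hydrogen on the aromatic carbon gives a 1.6-fold higher number from compound 1 to compound 3 (0.20 log units; within the scatter). The aromatic ring on this nitrogen has therefore now carried either a methyl or a chloro with no change beyond the scatter, across these three compounds. Nothing available explains why the numbers stay so close. Still open, from the compounds shown here alone, is whether an amine or a carboxylic acid on this ring, or a longer chain in its place, would shift the number beyond the scatter.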